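A Thiazole Swap and the Cell Tolerance Expected From It

The source may hold more compounds than are shown below. What is called first, only, known or untested is meant among the compounds shown, and "the series" means these compounds.

Compound 1 `O=C1CC(c2cnc(C(F)(F)F)s2)CN1c1cnn2c1CN(C(=O)Nc1cc(F)c(F)c(F)c1)C(C1CC1)C2` gives 38500 nM in a toxicity assay on HepG2 2.2.15 cells (Homo sapiens) for cytotoxicity, read by CellTiter-Glo; a lower number here means that less compound is tolerated, a higher number that more compound is tolerated.
Compound 2 `O=C1CC(c2ccccc2)CN1c1cnn2c1CN(C(=O)Nc1cc(F)c(F)c(F)c1)C(Cc1ccccc1)C2` gives > 2000 nM in this assay, which is a limit of the assay and not a number.
Compound 3 `CC1CCn2ncc(N3CC(c4ccccc4)CC3=O)c2CN1C(=O)Nc1cc(F)c(F)c(F)c1` gives > 2000 nM in this assay, again a limit rather than a number.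

Among these three, compound 1 is the only one with a definite value in this assay; the other two entries sit at the limit of > 2000 nM in this assay, at which 2 of the 3 values shown sit, so no ordering among the three can be drawn from them. Compound 4 `O=C1CC(c2nccs2)CN1c1cnn2c1CN(C(=O)Nc1cc(F)c(F)c(F)c1)C(C1CC1)C2` keeps the whole of the shared core and the urea with its trifluorophenyl group, and differs from compound 1 in one place only: 1,3-thiazol-2-yl in place of 2-(trifluoromethyl)-1,3-thiazol-5-yl on a saturated ring carbon. Within the data shown here, no measured pair in this set differs by a change of this kind, so there is no step to lean on. For a change confined to a small aromatic group on a saturated ring carbon, the expectation is a step from compound 1 to compound 4 of no more than the usual scatter, in either direction. Compound 4 is therefore estimated to give 40000 nM in this assay, within a range of 15000 nM to 100000 nM, which amounts to an expected step of a 1.0-fold higher number from compound 1 to compound 4 (0.02 log units; within the scatter).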

Compound 4, half-maximal cytotoxic concentration: 115000 nM
Compound 4: the middle estimate sits 2.9-fold (0.46 log units) below what was measured; measured number above the stated range.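

Among these compounds, this is the first readable step at this position: the swap of 2-(trifluoromethyl)-1,3-thiazol-5-yl for 1,3-thiazol-2-yl gives a 3.0-fold higher number from compound 1 to compound 4 (0.48 log units; beyond the scatter) in this assay, so more compound is tolerated. A change confined to this small aromatic group on a saturated ring carbon can therefore shift cell tolerance beyond the scatter, with the shared core and the urea untouched. Compounds 2 and 3 could not show this, as each entry is a limit and not a number: the limit of > 2000 nM in this assay, at which 2 of the 4 values shown sit.

The step joins two changes, the loss of the trifluoromethyl group and a different point of attachment on the thiazole, and the compounds shown cannot separate them. On these data alone, a plain 1,3-thiazol-5-yl group at this carbon would separate them, and it remains open how a 2-methyl-1,3-thiazol-5-yl group would fare.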